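From 4-fluorophenyl to 4-(trifluoromethyl)phenyl in a halogen series

A few compounds are considered here, and "the series" means these few. Any claim that something is new, unique, unknown or untested is made for them only; others in the source may bear on it.

In a functional assay on HeLa cells (Homo sapiens) for antiproliferative activity, read by MTT assay, with a stated time of 24 h (on this read-out lower numbers stand for stronger inhibition and higher numbers for weaker inhibition), compound 1 `O=S(=O)(c1ccc(F)cc1)n1c(-c2cn(-c3ccccc3)nc2-c2ccc(F)cc2)nc2ccccc21` gives 2440 nM, compound 2 `O=S(=O)(c1ccc(Cl)cc1)n1c(-c2cn(-c3ccccc3)nc2-c2ccc(F)cc2)nc2ccccc21` gives 3450 nM and compound 3 `O=S(=O)(c1ccc(Br)cc1)n1c(-c2cn(-c3ccccc3)nc2-c2ccc(F)cc2)nc2ccccc21` gives 2040 nM. Compound 2 stands within the scatter of both others, as shown by a 1.4-fold higher number from compound 1 to compound 2 (0.15 log units; within the scatter) and a 1.7-fold lower number from compound 2 to compound 3 (0.23 log units; within the scatter). The remaining step, a 1.2-fold lower number from compound 1 to compound 3 (0.08 log units; within the scatter), is also within the scatter.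

Compound 4 `O=S(=O)(c1ccc(Cl)cc1)n1c(-c2cn(-c3ccccc3)nc2-c2ccc(C(F)(F)F)cc2)nc2ccccc21` keeps the chloro group of compound 2 but has trifluoromethyl in place of fluoro on an aromatic carbon, para to a large group: trifluoromethyl in place of fluoro on an aromatic carbon. The measured steps bear on this change only indirectly. Each exchanges one halogen for another, and none varies the 4-fluorophenyl group. For the measured compounds named here, the only guide is the small size of those steps, such as a 1.7-fold lower number from compound 2 to compound 3 (0.23 log units; within the scatter) leading to compound 3. No step beyond the scatter is therefore expected, and the estimated change is a 1.1-fold lower number from compound 2 to compound 4 (0.03 log units; within the scatter), with no firm direction. For compound 4 the expected value is 3200 nM, with an estimated range from 1400 nM to 7500 nM.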

Compound 4, half-maximal inhibitory concentration: 3060 nM
For compound 4 the middle estimate is 1.0-fold (0.02 log units) above the measured one; low and high end bracket the measured number.
By their numbers in this assay, from the lowest: compounds 3, 1, 4 and 2 (each within the scatter of the next).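

In this assay, the exchange of 4-fluorophenyl for 4-(trifluoromethyl)phenyl gives a 1.1-fold lower number from compound 2 to compound 4 (0.05 log units; within the scatter) and so shows that this place, on which the halogen exchanges among compound 1, compound 2 and compound 3 had no bearing, can take 4 heavy atoms instead of 1 heavy atom without a step beyond the scatter. This rests on a single pair, compound 2 and compound 4, both carrying the chloro group. The data offer no measurement that would explain this result.

On these data alone, it remains open whether the same exchange gives a similar step when the chloro group is replaced by fluoro or bromo. As far as these compounds go, it also remains open whether an amine or a carboxylic acid at this place would stay within the scatter of compound 2.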